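Fluoro in place of acetyl on the shared core

The source may report more compounds than this note shows. Statements on the series, on what has been measured and on what is new or still open speak of the compounds shown alone.

Measured compounds:
Compound 1, `CCc1ccc(Nc2nc3nonc3nc2O)cc1`: 10700 nM
Compound 2, `CC(C)(C)c1ccc(Nc2nc3nonc3nc2O)cc1`: 3900 nM
Compound 3, `CC(=O)c1ccc(Nc2nc3nonc3nc2O)cc1`: 93700 nM

In an assay on mitochondria from L6 cells (Rattus norvegicus) for activation, with a stated time of 90 min (a lower number here means that less compound is needed, a higher number that more compound is needed for the effect), compound 3 gives the highest number of the three, with compound 1 nearest and compound 2 furthest. The steps among the alkyl-bearing compounds run in the opposite direction: a 2.7-fold lower number from compound 1 to compound 2 (0.44 log units; beyond the scatter), whereas the acetyl compound sits far off, since an 8.8-fold higher number from compound 1 to compound 3 (0.94 log units; beyond the scatter) and a 24-fold higher number from compound 2 to compound 3 (1.38 log units; beyond the scatter).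

Compound 4, `Oc1nc2nonc2nc1Nc1ccc(F)cc1`, is not yet measured in this assay. Its difference from compound 3 is fluoro in place of acetyl on an aromatic carbon. Within the data shown here, the steps that bear on it are those into compound 3 from compound 1 and compound 2, both of which went upward by a modest to large amount when acetyl entered. Among the measured compounds shown here, removing acetyl is therefore expected to lower the number, though fluoro is far smaller than ethyl or tert-butyl and no step here tells how a small group in that place behaves. The step from compound 3 to compound 4 is expected to be a 6.2-fold lower number from compound 3 to compound 4 (0.80 log units; beyond the scatter), toward the region of compound 1. Compound 4 is thus estimated at 15000 nM, with a range from 4000 nM to 60000 nM.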

Compound 4, half-maximal effective concentration: 38600 nM
Beside the measured number, compound 4's estimate is 2.6-fold (0.41 log units) below it, within the range that was stated.
By their numbers in this assay, from the lowest: compound 2; then compound 1; then compound 4; then compound 3.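

In this assay, fluoro is the smallest group seen on this aromatic carbon, and replacing acetyl with it recovers only part of the distance to the alkyl compounds, with a 2.4-fold lower number from compound 3 to compound 4 (0.39 log units; beyond the scatter). Fluoro still stands clearly on the high side of both alkyl groups, with a 3.6-fold higher number from compound 1 to compound 4 (0.56 log units; beyond the scatter) and a 9.9-fold higher number from compound 2 to compound 4 (1.00 log units; beyond the scatter), so the number does not follow group size alone: the alkyl groups, both larger than fluoro, give lower numbers, while acetyl, also larger, goes against them and gives the highest. No measurement is available to explain this order.

The compounds shown leave open whether chloro, methoxy or a longer chain such as n-butyl would fall with the alkyl groups or nearer fluoro. They also leave open where an amine or a carboxylic acid on this carbon would stand.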